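Carboxy in Place of Hydrogen on the Anilino Ring

The source may report more compounds than this note shows. Statements on the series, on what has been measured and on what is new or still open speak of the compounds shown alone.

Measured so far:
compound 1 `CN(c1nc2c(Nc3ccc(C(F)(F)F)cc3)ncnc2s1)c1c(Cl)cccc1Cl`: 502 nM
compound 2 `FC(F)(F)c1cccc(Nc2ncnc3sc(Nc4c(Cl)cccc4Cl)nc23)c1`: 206 nM
compound 3 `Clc1cccc(Cl)c1Nc1nc2c(Nc3ccccc3)ncnc2s1`: 176 nM

In a functional assay on HEK293 cells for antagonist activity at transient receptor potential cation channel subfamily V member 1 (Homo sapiens), read by calcium flux (on this read-out lower numbers stand for stronger inhibition and higher numbers for weaker inhibition), compound 3 gives 176 nM, the lowest of the three numbers. Compound 2 is nearest, and the step of a 1.2-fold lower number from compound 2 to compound 3 (0.07 log units; within the scatter) lies within the scatter, so the two are not distinguished. Compound 1 stands furthest, giving 502 nM in this assay, a gap beyond the scatter.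

Compound 4 `O=C(O)c1ccc(Nc2ncnc3sc(Nc4c(Cl)cccc4Cl)nc23)cc1` differs from compound 3 by carboxy in place of hydrogen on an aromatic carbon, sitting para to a large group on the six-membered aromatic ring of carbon only. Within the data shown here, no measured step shows a carboxy entering; the only step on that ring, a 1.2-fold lower number from compound 2 to compound 3 (0.07 log units; within the scatter), concerns trifluoromethyl and is within the scatter. The data therefore give no direct guide, and the expectation rests on the change itself. A weaker result is estimated, the step of a 6.8-fold higher number from compound 3 to compound 4 (0.83 log units; beyond the scatter) being expected in this assay. Compound 4 is expected to give about 1200 nM, within 250 nM to 6000 nM.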

Compound 4, half-maximal inhibitory concentration: > 5000 nM
Compound 4: a limit, no number (the forecaster's own chance of this, stated with the estimate: 25%); middle value at least 4.1-fold (0.61 log units) from the limit.
By their numbers in this assay, from the lowest: compounds 3 and 2 (each within the scatter of the next); then compound 1. At a limit, above all of these: compound 4.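

Compound 4 reads in this assay as a limit and not a number: the limit of > 5000 nM in this assay, at which 1 of the 4 values shown sits. Among these compounds, with carboxy in place of hydrogen on an aromatic carbon, para to a large group, the ring gives an at least 28-fold higher number from compound 3 to compound 4 (1.45 log units; beyond the scatter), the first step on this ring beyond the scatter, whereas the earlier step, a 1.2-fold lower number from compound 2 to compound 3 (0.07 log units; within the scatter), stayed within it. The ring is therefore not indifferent to what it carries, and the entry of carboxy alone is enough to take compound 4 out of the range that compounds 1, 2 and 3 occupy.

The compounds shown leave open how a methyl ester, an amide or an amine at this same place would read, and so whether the loss belongs to carboxy specifically. On these data alone, how far the true value of compound 4 lies beyond its limit also stays unknown.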